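Dimethylamino in place of methoxy: working notes

The source may hold more compounds than are shown below. What is called first, only, known or untested is meant among the compounds shown, and "the series" means these compounds.

Within the data shown here, in a functional assay on A549 cells (Homo sapiens) for inhibition, read by sulforhodamine B assay (a lower number here means a stronger inhibitor of growth, a higher number a weaker inhibitor of growth), compound 1 (`Oc1cccc2[nH]c(-c3ccc(-c4ccc(-c5ccc(OC(F)(F)F)cc5)cc4)cc3)nc12`) gives 190 nM and compound 2 (`COc1ccc(-c2ccc(-c3ccc(-c4nc5c(O)cccc5[nH]4)cc3)cc2)cc1`) gives 7690 nM, the higher of the two numbers measured so far. Compound 3 (`CN(C)c1ccc(-c2ccc(-c3ccc(-c4nc5c(O)cccc5[nH]4)cc3)cc2)cc1`) keeps the rest of compound 2 and carries dimethylamino in place of methoxy on an aromatic carbon, para to a large group: dimethylamino in place of methoxy on an aromatic carbon.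

Among the measured compounds shown here, only one measured step bears on this change: a 40-fold higher number from compound 1 to compound 2 (1.61 log units; beyond the scatter). That step is large and beyond the scatter, and it alters the same methoxy group, so the series does respond to a change there. For the measured compounds named here, it is, however, a different exchange, and no measured compound carries dimethylamino, so the data give no firm direction. A step of that size is not assumed here, and only a slight lean towards a lower number is allowed for. The expected step in this assay is a 1.5-fold lower number from compound 2 to compound 3 (0.19 log units; within the scatter), with no clear move beyond the scatter anticipated. For compound 3 the estimated value is 5000 nM, with an expected range of 1200 nM to 20000 nM.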

Compound 3, concentration for 50% growth inhibition: 7100 nM
Beside the measured number, compound 3's estimate is 1.4-fold (0.15 log units) below it; measured number inside the range.
By their numbers in this assay, from the lowest: compound 1; then compounds 3 and 2 (each within the scatter of the next).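

In this assay, among these compounds, dimethylamino in place of methoxy gives a 1.1-fold lower number from compound 2 to compound 3 (0.03 log units; within the scatter), so this position also admits an exchange that leaves the number within the scatter, whereas the only earlier step there was large. Trifluoromethoxy now stands apart from two other groups rather than one: the change to dimethylamino gives a 37-fold higher number from compound 1 to compound 3 (1.57 log units; beyond the scatter) and is large, as is the change to methoxy, a 40-fold higher number from compound 1 to compound 2 (1.61 log units; beyond the scatter), with compound 2 and compound 3 lying within the scatter of each other. No measurement at hand accounts for either the match between methoxy and dimethylamino or the gap to trifluoromethoxy.

The compounds shown leave open whether trifluoromethyl, chloro or a nitrile on the same aromatic carbon would give a number nearer that of compound 1 or nearer that of compound 3, and so whether the lower number belongs to trifluoromethoxy alone. Also open is where a longer chain such as ethoxy, a primary amine or a carboxylic acid at this position would fall, since the three groups shown cover only a narrow set of substituents.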